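The source may report more compounds than this note shows. Statements on the series, on what has been measured and on what is new or still open speak of the compounds shown alone.

Measured so far in a functional assay on WI-38 VA13 cells (Homo sapiens) for cytotoxicity; a higher number here means that more compound is needed for the effect, a lower number that less compound is needed:
compound 1 `O=C(Nc1ccc2nc(NC(=O)C3CCCCC3)sc2c1)c1ccc(Cl)cc1Cl` — > 4 ug/mL, a limit of the assay
compound 2 `CC(=O)Nc1nc2ccc(NC(=O)c3c(Cl)cccc3Cl)cc2s1` — 0.6 ug/mL
compound 3 `O=C(O)CCC(=O)Nc1nc2ccc(NC(=O)c3c(Cl)cccc3Cl)cc2s1` — > 6.6 ug/mL, a limit of the assay

Compound 3 sits at a limit in this assay; no number is known for it, only the bound (the limit of > 6.6 ug/mL in this assay, at which 1 of the 3 values shown sits). Compound 1 likewise stands at a limit, (the limit of > 4 ug/mL in this assay, at which 1 of the 3 values shown sits). For the measured compounds named here, the only step with a number on one side is an at least 11-fold higher number from compound 2 to compound 3 (1.04 log units; beyond the scatter), where compound 2 alone gives a measured value.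

Compound 4 `O=C(Nc1nc2ccc(NC(=O)c3c(Cl)cccc3Cl)cc2s1)OCc1ccccc1` is not yet measured. It differs from compound 3 by benzyloxy in place of 2-carboxyethyl on a carbonyl carbon. Going by the values given here, the change runs opposite to the one that took compound 2 to compound 3: the carboxylic acid that entered there leaves here, and an aromatic ring comes in. Among the compounds with values here, the one measured step, an at least 11-fold higher number from compound 2 to compound 3 (1.04 log units; beyond the scatter), bears on this, but compound 1, carrying a cyclohexyl on the same carbonyl, also gives only a limit, so a larger uncharged group does not by itself bring the number back down. The step from compound 3 to compound 4 in this assay is therefore expected to be an at least 2.2-fold lower number from compound 3 to compound 4 (0.34 log units; beyond the scatter), downward but uncertain, with a real chance that compound 4 again reports only a limit. Compound 4 is estimated at 3 ug/mL, within 0.6 ug/mL to 15 ug/mL.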

Compound 4, half-maximal effective concentration: 0.018 ug/mL
Estimate against measurement, compound 4: 170-fold (2.22 log units) above; the measured number lies below the stated range.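

The group on this carbonyl carbon can drive the number down as well as up: with benzyloxy in place of methyl, this assay shows a 33-fold lower number from compound 2 to compound 4 (1.52 log units; beyond the scatter). With benzyloxy in place of 2-carboxyethyl, the same assay shows an at least 360-fold lower number from compound 3 to compound 4 (2.56 log units; beyond the scatter), so the two changes at this one place run in opposite directions from compound 2, one to a limit and one to a far lower measured number. The size of the step from the acid-bearing chain is only a bound, as compound 3 stands at a limit of the assay: the limit of > 6.6 ug/mL in this assay, at which 1 of the 4 values shown sits.

For the compounds shown here, compound 1, with cyclohexyl on the same carbonyl carbon, is also a limit of the assay and differs from the other compounds in more than one place, so no step to it can be read: the limit of > 4 ug/mL in this assay, at which 1 of the 4 values shown sits. It remains open whether the aromatic ring or the oxygen of benzyloxy carries the drop, which a methoxy or a 2-phenylethyl on the same carbonyl carbon would help separate.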